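Extending the side chain on two related cores

The compounds below may be only part of what the source reports. "The series", "measured", "known", "first", "only" and "open" are said of these compounds alone.

Three compounds have been measured in an assay on isolated protein for inhibition of Polyunsaturated fatty acid 5-lipoxygenase (Homo sapiens), read by ELISA, with a stated time of 10 min; on this read-out higher numbers stand for weaker inhibition and lower numbers for stronger inhibition:

Compound 1 `CCCCCCCCCCCCCC1=CC(=O)C=C(OC)C1=O` gives 1050 nM
Compound 2 `CCCCCCCCCCCc1cc(O)cc(OC)c1O` gives 280 nM
Compound 3 `CCCCCCCCCCCCCCCC1=CC(=O)C=C(OC)C1=O` gives 790 nM

Compound 3 differs from compound 1 by ethyl in place of hydrogen on a saturated chain carbon, ten or more bonds along the chain from a double-bonded ring carbon, and in this assay that change made a step of a 1.3-fold lower number from compound 1 to compound 3 (0.12 log units; within the scatter). Compound 2 rests on a different core; the difference between the two cores is not broken down here. In this assay compound 2 gives the lowest of the three numbers, and its gaps to compound 3 and to compound 1 both lie beyond the scatter.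

Compound 4 `CCCCCCCCCCCCCc1cc(O)cc(OC)c1O` has not yet been measured. It differs from compound 2 by ethyl in place of hydrogen on a saturated chain carbon, ten or more bonds along the chain from an aromatic carbon. For the measured compounds named here, this is the same kind of change as the one from compound 1 to compound 3, not the same one: the two differ only in the kind of ring carbon the chain is counted from, a double-bonded ring carbon there and an aromatic carbon here. Since that change gave only a 1.3-fold lower number from compound 1 to compound 3 (0.12 log units; within the scatter) on the core of compound 1, a step of similar size is expected here, resting on that single pair alone. The expected step is a 1.2-fold lower number from compound 2 to compound 4 (0.09 log units; within the scatter). Compound 4 is therefore estimated at 230 nM, most likely between 120 nM and 450 nM.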

Compound 4, half-maximal inhibitory concentration: 1490 nM
The estimate for compound 4 lay 6.5-fold (0.81 log units) below the measured number; measured number above the stated range.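

In this assay, ethyl in place of hydrogen on a saturated chain carbon, ten or more bonds along the chain from an aromatic carbon, gave a 5.3-fold higher number from compound 2 to compound 4 (0.73 log units; beyond the scatter) and so weakened inhibition on the core of compound 2. For the compounds shown here, each core offers only one pair, so these results do not show how the change would behave on any further core, nor which feature of the two cores sets the steps apart. They do show that, in this series, the size and direction of this change on one core cannot be assumed to hold on the other: the same change on two cores in this assay, a 1.3-fold lower number (0.12 log units; within the scatter) from compound 1 to compound 3 and a 5.3-fold higher number (0.73 log units; beyond the scatter) from compound 2 to compound 4, 7.1-fold (0.85 log units) apart, beyond the scatter of two such steps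

The compounds shown leave open how inhibition follows chain length on either core, since a shorter chain or a longer chain would be needed to tell a steady trend from an abrupt drop. They also leave open whether a chain ending in a carboxylic acid or an amine would follow the same course on both cores.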